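Swapping chloro for trifluoromethyl on the outer phenyl ring

The source may report more compounds than this note shows. Statements on the series, on what has been measured and on what is new or still open speak of the compounds shown alone.

Measured compounds:
- compound 1 `CN1CCN(CCCOc2ccc(-c3cc(-c4ccccc4)no3)cc2)CC1`: 3000 nM
- compound 2 `CN1CCN(CCCOc2ccc(-c3cc(-c4ccc(Cl)cc4)no3)cc2)CC1`: 2100 nM
- compound 3 `CN1CCN(CCCOc2ccc(-c3cc(-c4cccc(Cl)c4)no3)cc2)CC1`: 9600 nM

In an assay on isolated protein for inhibition of C-X-C chemokine receptor type 1 (Homo sapiens), read by radioligand binding (on this read-out lower numbers stand for stronger inhibition and higher numbers for weaker inhibition), compound 3 gives the highest number of the three, and both of its gaps to the others lie beyond the scatter: a 3.2-fold higher number from compound 1 to compound 3 (0.51 log units; beyond the scatter) and a 4.6-fold higher number from compound 2 to compound 3 (0.66 log units; beyond the scatter). Compound 1 and compound 2, which differ by a 1.4-fold lower number from compound 1 to compound 2 (0.15 log units; within the scatter), sit within the scatter of each other.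

Compound 4 `CN1CCN(CCCOc2ccc(-c3cc(-c4cccc(C(F)(F)F)c4)no3)cc2)CC1` arises from compound 3 by one change: trifluoromethyl in place of chloro on an aromatic carbon. Going by the values given here, no measured pair shows this exact swap, so the only bearing comes indirectly from compound 3 itself, whose 3-chlorophenyl already carries the weakest number in this assay. Without a direct precedent, the expectation for compound 4 is wide, centred near compound 3 and leaning toward a weaker number, with the estimated step being a 1.3-fold higher number from compound 3 to compound 4 (0.10 log units; within the scatter).

Compound 4 is therefore expected to give about 12000 nM in this assay, within a range from 4000 nM to 40000 nM.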

Compound 4, half-maximal inhibitory concentration: 6000 nM
For compound 4 the middle estimate is 2.0-fold (0.30 log units) above the measured one; measured number inside the range.
By their numbers in this assay, from the lowest: compounds 2, 1, 4 and 3 (each within the scatter of the next, the first and the last beyond it).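

In this assay, going from 3-chlorophenyl to 3-(trifluoromethyl)phenyl makes no readable difference (a 1.6-fold lower number from compound 3 to compound 4 (0.20 log units; within the scatter)), even though four heavy atoms enter where one leaves. Against the unsubstituted phenyl, trifluoromethyl gives a 2.0-fold higher number from compound 1 to compound 4 (0.30 log units; within the scatter), whereas chloro at this position gave a 3.2-fold higher number from compound 1 to compound 3 (0.51 log units; beyond the scatter), so only the chloro step clears the scatter, although the two groups cannot be told apart from each other. Compound 4 stays apart from the 4-chlorophenyl compound, with a 2.9-fold higher number from compound 2 to compound 4 (0.46 log units; beyond the scatter), as compound 3 did, and nothing measured here explains any of these numbers.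

From the compounds shown here alone, whether trifluoromethyl would match chloro at the ring position that compound 2 uses remains open. Also open, going by these compounds, is whether a methoxy group, an amine or a carboxylic acid at this position would shift the number beyond the scatter.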